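The compounds below may be only part of what the source reports. "The series", "measured", "known", "first", "only" and "open" are said of these compounds alone.

Compound 1 `Cc1ccc(S(=O)(=O)N2CC(c3ccccc3)NC2=O)cc1` and compound 2 `O=C1NC(c2ccccc2)CN1S(=O)(=O)c1ccc(Cl)cc1` share a core that carries a sulfonyl-linked aromatic ring, and in a functional assay on A549 cells (Homo sapiens) for cytotoxicity (a higher number here means a weaker inhibitor, a lower number a stronger inhibitor), compound 1 gives 12500 nM while compound 2 gives 9470 nM. Between them stands one change, (methyl in place of chloro on an aromatic carbon), and the step of a 1.3-fold higher number from compound 2 to compound 1 (0.12 log units; within the scatter) is small. Compound 3 `Cc1ccc(C2CNC(=O)N2S(=O)(=O)c2ccc(Cl)cc2)cc1` belongs to a different core; the difference between the two cores is not broken down here. In this assay compound 3 gives 266000 nM, the highest of the three numbers and beyond the scatter from both compound 1 and compound 2. Compound 4 `Cc1ccc(C2CNC(=O)N2S(=O)(=O)c2ccc(C)cc2)cc1` is not yet measured and differs from compound 3 by methyl in place of chloro on an aromatic carbon, the same change that separates compound 2 from compound 1, at a place described in the same words. The expected step for compound 4 is therefore a 1.2-fold higher number from compound 3 to compound 4 (0.08 log units; within the scatter), resting on the single earlier case, compound 2 to compound 1 with a 1.3-fold higher number from compound 2 to compound 1 (0.12 log units; within the scatter), which stayed within the scatter. On that basis compound 4 is estimated at 320000 nM, with a likely range from 110000 nM to 950000 nM.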

Compound 4, half-maximal inhibitory concentration: > 302000 nM
Compound 4 gave a limit, no number; the forecaster's own chance of this, stated with the estimate: 25%; the middle value is on the limit's open side.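

In this assay compound 4 gave only a limit of the assay and not a number: > 302000 nM. The change from chloro to methyl therefore reads as an at least 1.1-fold higher number from compound 3 to compound 4 (0.05 log units; that floor lies within the scatter), which is a floor and not a size, so the result is compatible with the change carrying over from one core to the other but does not show that it does, and a much larger step on this core remains possible. Set beside the only other case in the series, and resting on just two cores, the comparison reads: the same change on two cores in this assay, a 1.3-fold higher number (0.12 log units; within the scatter) from compound 2 to compound 1 and an at least 1.1-fold higher number (0.05 log units; that floor lies within the scatter) from compound 3 to compound 4; the limit leaves it open whether they differ.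

The compounds shown leave open how large the step on the core of compound 3 really is, since no number exists for compound 4. They also leave open whether other groups at the same aromatic carbon, such as fluoro, methoxy or an amine, would behave alike on both cores.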